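A cytotoxicity estimate for compound 4

The compounds below may be only part of what the source reports. "The series", "measured", "known", "first", "only" and "open" are said of these compounds alone.

Measured in an ADME assay on ECV-304 cells (Homo sapiens) for cytotoxicity, read by MTT assay, with a stated time of 72 h; a higher number here means a weaker inhibitor, a lower number a stronger inhibitor:
- Compound 1 `COc1ccc(C2=C(c3cc(OC)c(OC)c(OC)c3)C(=O)C(OC(C)=O)C2)cc1`: 18 ug/mL
- Compound 2 `COC(=O)c1cc(C2=C(c3cc(OC)c(OC)c(OC)c3)C(=O)CC2O[SiH2]C(C)(C)C)ccc1OC`: > 100 ug/mL
- Compound 3 `COc1cc(C2=C(c3ccc(OCC(=O)O)cc3)C(O)CC2=O)cc(OC)c1OC`: "not determined" (no result reported)

Compound 2 gives > 100 ug/mL in this assay, and this is a limit of the assay, not a number. Compound 2 therefore stands at the limit of > 100 ug/mL in this assay, at which 1 of the 3 values shown sits. Compound 1, at 18 ug/mL, is the only one of the three with a single number, and compound 3 offers no result to compare.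

Compound 4 `COc1cc(C2=C(c3cc(C)c(OC)c(C)c3)C(O[SiH2]C(C)(C)C)CC2=O)cc(OC)c1OC` is still to be measured in this assay. It departs from compound 2 at one place, with 4-methoxy-3,5-dimethylphenyl in place of 4-methoxy-3-(methoxycarbonyl)phenyl on a double-bonded ring carbon. For the measured compounds named here, no pair of measured compounds shows what this exchange does, so its size cannot be read from the data. Going by the values given here, the one number available, compound 1 at 18 ug/mL, anchors the expectation, which is a move toward stronger inhibition. The expected change is an at least 2.8-fold lower number from compound 2 to compound 4 (0.45 log units; beyond the scatter), although a second result reported only as a limit would not be a surprise. For compound 4 the estimated value is 35 ug/mL, with an expected range from 7 ug/mL to 100 ug/mL.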

Compound 4, half-maximal inhibitory concentration: 15 ug/mL
Compound 4: the middle estimate sits 2.3-fold (0.37 log units) above what was measured, within the range that was stated.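

In this assay, for the compounds shown here, putting 4-methoxy-3,5-dimethylphenyl in place of 4-methoxy-3-(methoxycarbonyl)phenyl on a double-bonded ring carbon gives the first readable step at this position: an at least 6.6-fold lower number from compound 2 to compound 4 (0.82 log units; beyond the scatter). The earlier compounds shown here offered no pair from which any change at this place could be read, and compound 4, at 15 ug/mL, now shows that the group on this ring carbon can decide whether a compound with the tert-butylsilyl ether gives a single number in this assay at all. As far as these compounds go, the true size of the step remains unknown, because compound 2 gives a limit of the assay and not a number: the limit of > 100 ug/mL in this assay, at which 1 of the 4 values shown sits.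

The compounds shown leave open how the step divides between losing the methoxycarbonyl group and gaining the methyl groups, as this single pair changes both at once. They also leave open whether an amine or a carboxylic acid on the same phenyl ring would lower the number as well, and whether the step would hold on a compound without the tert-butylsilyl ether.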